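A few compounds are considered here, and "the series" means these few. Any claim that something is new, unique, unknown or untested is made for them only; others in the source may bear on it.

Working notes on the series. Compound 3 `COc1ccccc1NC(=O)c1c(O)c2cccnc2n(-c2ccccc2)c1=O` stands second highest of the three numbers to hand in a functional assay on the whole organism for inhibition, with Rattus norvegicus as the target, read by cytopathic effect and paw edema, at a dose of 100 mg/kg by the oral route (a higher number here means more inhibition at the dose given (going by the name of the read-out), a lower number less inhibition), where compound 3 gives -10.1%. Above it stands compound 2 `O=C(Nc1cccc(Cl)c1)c1c(O)c2cccnc2n(-c2ccccc2)c1=O`, which gives 13.4%; below it compound 1 `O=C(NN1CCOCC1)c1c(O)c2cccnc2n(-c2ccccc2)c1=O`, which gives -26.2%. The two steps from the morpholin-4-yl amide are a number 39.6 percentage points higher from compound 1 to compound 2 (beyond the scatter) and a number 16.1 percentage points higher from compound 1 to compound 3 (beyond the scatter), so either aryl amide lies beyond the scatter above compound 1.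

Compound 4 `O=C(Nc1ccc(Cl)nc1)c1c(O)c2cccnc2n(-c2ccccc2)c1=O` is not yet measured in this assay. It differs from compound 3 by 6-chloropyridin-3-yl in place of 2-methoxyphenyl on an amide-type nitrogen. Among the compounds with values here, the one measured step that bears directly on this change is a number 23.5 percentage points lower from compound 2 to compound 3 (beyond the scatter), a step from a chlorine-bearing aryl to the 2-methoxyphenyl. The change to compound 4 runs the other way, back to a chlorine-bearing aryl, and a rise in this assay is therefore expected, though 6-chloropyridin-3-yl is not 3-chlorophenyl and the expected gain is held short of that full step, about a number 15.1 percentage points higher from compound 3 to compound 4 (beyond the scatter). For compound 4 the estimate is 5%, with a range from -15% to 25%.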

Compound 4, a percentage reported as inhibition, in the whole organism at one dose (the size of the read-out at that dose, not a potency): -4%
The estimate for compound 4 lay 9 percentage points above the measured number, within the range that was stated.
By their numbers in this assay, from the lowest: compound 1; then compounds 3 and 4 (each within the scatter of the next); then compound 2.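

On the amide-type nitrogen, a chlorine on the aromatic ring does not by itself bring the number up to that of compound 2 in this assay: the step is a number 17.4 percentage points lower from compound 2 to compound 4 (beyond the scatter), while the change from 2-methoxyphenyl to 6-chloropyridin-3-yl gives a number 6.1 percentage points higher from compound 3 to compound 4 (within the scatter), so these two groups cannot be told apart here. With a number 22.2 percentage points higher from compound 1 to compound 4 (beyond the scatter), all three aromatic amides now stand above the morpholin-4-yl amide, and none of the compounds shown goes against this. Nothing on hand explains the shortfall of 6-chloropyridin-3-yl against 3-chlorophenyl.

The compounds shown leave open whether the ring nitrogen or the place of the chlorine separates compound 2 from compound 4, a question that unsubstituted phenyl and pyridin-3-yl amides would address. Also open, going by these compounds, is how a benzyl group or a carboxylic acid on the aromatic ring would read at this nitrogen.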